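Exposure notes: step from compound 3 to compound 4

This account rests on a few compounds, and the source may have more. Where it says the series, first, only, none or still open, it means among the compounds named here.

Values in an ADME assay on the whole organism (Rattus norvegicus) for pharmacokinetics, at a dose of 10 mg/kg by the oral route (on this read-out lower numbers stand for lower exposure and higher numbers for higher exposure at the dose given), so far:
- compound 1 `COc1cc(N2CCC(C)(O)CC2)ccc1Nc1nc(O[C@H]2CCOC(C)(C)C2)c2cc[nH]c2n1` gives 5300 ng.h/mL
- compound 2 `COc1cc(C(=O)N(C)C)ccc1Nc1nc(O[C@H]2CCOC(C)(C)C2)c2cc[nH]c2n1` gives 13200 ng.h/mL
- compound 3 `COc1cc(N2CCN(C3COC3)CC2)ccc1Nc1nc(O[C@H]2CCOC(C)(C)C2)c2cc[nH]c2n1` gives 12200 ng.h/mL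

Compound 3 belongs with the upper pair of these values. Going by the values given here, the gap to its nearest neighbour is a 1.1-fold lower number from compound 2 to compound 3 (0.03 log units; within the scatter) and so gives no ordering of that pair, while the gap at the other end is a 2.3-fold higher number from compound 1 to compound 3 (0.36 log units; beyond the scatter) and counts as modest.

The next compound is compound 4 `COc1cc(N2CCN(C(=O)CO)CC2)ccc1Nc1nc(O[C@H]2CCOC(C)(C)C2)c2cc[nH]c2n1` with (hydroxymethyl)carbonyl in place of oxetan-3-yl on an amine nitrogen in a ring. Counted, the difference is (hydroxymethyl)carbonyl in place of oxetan-3-yl on an amine nitrogen in a ring and no measured step covers this exchange directly. The measured steps all replace a group on an aromatic carbon, and the other one, a 2.5-fold higher number from compound 1 to compound 2 (0.40 log units; beyond the scatter) is also modest, so nothing points to a large move in this assay here. Among the compounds with values here, compound 1 is the only measured compound with a hydroxy in the varied group and is the lowest of the three, which is a single case and supports only a weak lean downward. The expected move is a 1.5-fold lower number from compound 3 to compound 4 (0.18 log units; within the scatter) and is estimated to stay small. For compound 4 the expected value is 8000 ng.h/mL with an estimated range from 3500 ng.h/mL to 16000 ng.h/mL as its limits.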

Compound 4, area under the concentration-time curve: 4850 ng.h/mL
Estimate against measurement, compound 4: 1.6-fold (0.22 log units) above; low and high end bracket the measured number.
By their numbers in this assay, from the lowest: compounds 4 and 1 (each within the scatter of the next); then compounds 3 and 2 (each within the scatter of the next).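

In this assay, going by these compounds alone, the amine nitrogen in a ring proves responsive: (hydroxymethyl)carbonyl in place of oxetan-3-yl gives a 2.5-fold lower number from compound 3 to compound 4 (0.40 log units; beyond the scatter) and is the first modest step seen at this place, all earlier steps having replaced a group on an aromatic carbon. A substituted piperazine therefore does not by itself hold the upper level, since the new group gives a 2.7-fold lower number from compound 2 to compound 4 (0.43 log units; beyond the scatter) and also a 1.1-fold lower number from compound 1 to compound 4 (0.04 log units; within the scatter) so that compound 4 has no order against the 4-hydroxy-4-methylpiperidin-1-yl compound. Among these four, the two compounds with a hydroxy in the varied group, compound 1 and compound 4, form the lower pair and none goes against this, though four compounds are a thin base for any pattern.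

The step removes a ring and brings in a carbonyl and a hydroxy at once, so acetyl, which has the carbonyl without the hydroxy, and 2-hydroxyethyl, which has the hydroxy without the carbonyl, on the same nitrogen would be needed to separate these changes. Nothing available here accounts for the lower exposure.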